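The source may report more compounds than this note shows. Statements on the series, on what has been measured and on what is new or still open speak of the compounds shown alone.

Measured so far:
Compound 1, `Cc1cc(NC(=O)Nc2ccc(Cl)c(Cl)c2)c2ccccc2n1`: 10000 nM in an ADME assay on Raji cells (Homo sapiens) for cytotoxicity, with a stated time of 72 h; on this read-out higher numbers stand for an effect only at larger amounts of compound and lower numbers for an effect already at smaller amounts
Compound 2, `CSc1ccc(NC(=O)Nc2cc(C)nc3ccccc23)cc1`: > 25000 nM in this assay
Compound 3, `COc1ccc(NC(=O)Nc2cc(C)nc3ccccc23)cc1F`: > 25000 nM in this assay

Of the compounds shown here, three sharing one core have been tested for cytotoxicity, and the readings are all weak. Compound 1 gives 10000 nM as a number. Compound 2 reaches only the limit of the assay, at > 25000 nM. Compound 3 likewise reaches only the limit of the assay, at > 25000 nM. So compound 2 stands at the edge of what the assay reports, and the limit of > 25000 nM in this assay, at which 2 of the 3 values shown sit, shows that it is not alone there.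

Among the compounds with values here, no pair among the measured compounds differs in a single place, so no step has been quantified. The next compound is compound 4, `Cc1cc(NC(=O)Nc2ccc(O)cc2)c2ccccc2n1`, which differs from compound 2 as follows: hydroxy in place of methylsulfanyl on an aromatic carbon.

The account leaves no basis for expecting a large step in this assay from this change. Compound 2 sits at a limit and compound 3 sits at a limit, so the estimate for compound 4 is expected to be a step of an at least 1.2-fold lower number from compound 2 to compound 4 (0.09 log units; that floor lies within the scatter), most probably again near the assay limit. Compound 4 is therefore estimated at 20000 nM, with a range from 8000 nM to 40000 nM.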

Compound 4, half-maximal effective concentration: > 25000 nM
Compound 4: no number, only a limit (the forecaster's own chance of this, stated with the estimate: 60%); at least 1.2-fold (0.09 log units) between middle value and limit.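

Compound 4 gives > 25000 nM in this assay as a limit of the assay and not a number. Compound 2 also stands at a limit, so no step can be read between compound 2 and compound 4: the limit of > 25000 nM in this assay, at which 3 of the 4 values shown sit. The compounds shown leave open whether hydroxy and methylsulfanyl differ at all on this read-out.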